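The source may hold more compounds than are shown below. What is called first, only, known or untested is meant among the compounds shown, and "the series" means these compounds.

Compound 1 `CCCCCCCCn1cc(/C=C/C(=O)c2ccc(NC(=O)CN3CCN(c4ccccc4F)CC3)cc2)nn1` gives 47100 nM in a functional assay on A549 cells (Homo sapiens) for inhibition, read by MTT assay; on this read-out higher numbers stand for weaker inhibition and lower numbers for stronger inhibition. Compound 2 `CCCCCCCCCCn1cc(/C=C/C(=O)c2ccc(NC(=O)CN3CCN(c4ccccc4)CC3)cc2)nn1` gives 52100 nM in this assay. Compound 3 `CCCCCCCCn1cc(/C=C/C(=O)c2ccc(NC(=O)CN3CCN(C(=O)OC(C)(C)C)CC3)cc2)nn1` gives 43300 nM in this assay.

Compound 3 stands at the lowest of the three numbers, but its nearest neighbour is compound 1 and its furthest is compound 2, and both of those gaps are small. For the measured compounds named here, the one step measured in one place, a 1.1-fold lower number from compound 1 to compound 3 (0.04 log units; within the scatter), is within the scatter, so the change of the group on the ring nitrogen left the number essentially where it was.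

Compound 4 `CCCCCCCCCCn1cc(/C=C/C(=O)c2ccc(NC(=O)CN3CCN(C(=O)OC(C)(C)C)CC3)cc2)nn1` differs from compound 3 by ethyl in place of hydrogen on a saturated chain carbon, eight bonds along the chain from an aromatic nitrogen. Going by the values given here, no measured step isolates this change. Among the compounds with values here, compound 2 carries the longer chain that compound 4 carries, but it also differs from compound 1 on the ring nitrogen, so the two values of compound 1 and compound 2 show only that the longer-chain compound sits close to the shorter-chain one. Within the data shown here, with no single-place step to go on and all three numbers crowded together, the expected step of a 1.1-fold higher number from compound 3 to compound 4 (0.04 log units; within the scatter) is none beyond the scatter. Compound 4 is therefore estimated at 47000 nM in this assay, with a range from 20000 nM to 110000 nM.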

Compound 4, half-maximal inhibitory concentration: 45400 nM
For compound 4 the middle estimate is 1.0-fold (0.02 log units) above the measured one; low and high end bracket the measured number.
By their numbers in this assay, from the lowest: compounds 3, 4, 1 and 2 (each within the scatter of the next).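

Ethyl in place of hydrogen on a saturated chain carbon, eight bonds along the chain from an aromatic nitrogen, now has a step of its own in this assay: a 1.0-fold higher number from compound 3 to compound 4 (0.02 log units; within the scatter), so this lengthening of the chain leaves the number where it was. The second new step, a 1.1-fold lower number from compound 2 to compound 4 (0.06 log units; within the scatter), gives a reading of the group on the amine nitrogen in a ring with the longer chain in place, and it stays within the scatter just as a 1.1-fold lower number from compound 1 to compound 3 (0.04 log units; within the scatter) did with the shorter chain. No measurement beyond these numbers bears on why the values stay together.

The compounds shown leave open whether any change at these two places moves the number beyond the scatter, for example a shorter chain such as butyl, or a free amine in place of tert-butoxycarbonyl on the amine nitrogen in a ring. It also stays open whether the same chain change reads alike with phenyl or 2-fluorophenyl on that nitrogen, since the only chain step shown carries tert-butoxycarbonyl.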